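Adding two methoxy groups to the ketone-side ring of compound 2

This account rests on a few compounds, and the source may have more. Where it says the series, first, only, none or still open, it means among the compounds named here.

Of the compounds shown here, two have been tested in a functional assay on MDA-MB-231 cells (Homo sapiens) for antiproliferative activity, read by MTT assay, with a stated time of 24 h; on this read-out higher numbers stand for weaker inhibition and lower numbers for stronger inhibition. Compound 1, `COc1ccc(-c2cc(/C=C/C(=O)c3ccc(OC)c(OC)c3)nc3cc(-c4ccccc4)nn23)cc1`, gives 8700 nM. Compound 2, `COc1cc(-c2cc(/C=C/C(=O)c3ccccc3)nc3cc(-c4ccccc4)nn23)cc(OC)c1OC`, gives 15800 nM, which is the higher of the two numbers, though the gap between them lies within the usual scatter, so neither can be called the stronger inhibitor. Compound 3, `COc1ccc(C(=O)/C=C/c2cc(-c3cc(OC)c(OC)c(OC)c3)n3nc(-c4ccccc4)cc3n2)cc1OC`, has not yet been measured. It differs from compound 2 in one place: 3,4-dimethoxyphenyl in place of phenyl on a carbonyl carbon. Compound 1 already carries this 3,4-dimethoxyphenyl on its carbonyl carbon and sits close to compound 2 in this assay, so no large move is expected from the change. The step of a 1.4-fold lower number from compound 2 to compound 3 (0.16 log units; within the scatter) is expected to stay within the scatter, leaning slightly toward a lower number. Compound 3 is therefore estimated at 11000 nM, with a plausible range from 5000 nM to 25000 nM.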

Compound 3, half-maximal inhibitory concentration: 18300 nM
The estimate for compound 3 lay 1.7-fold (0.22 log units) below the measured number, within the range that was stated.
By their numbers in this assay, from the lowest: compounds 1, 2 and 3 (each within the scatter of the next, the first and the last beyond it).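

In this assay, 3,4-dimethoxyphenyl in place of phenyl on the carbonyl carbon gives a 1.2-fold higher number from compound 2 to compound 3 (0.06 log units; within the scatter), so this position accepts the two added methoxy groups with no change that can be told from the scatter, at least while 3,4,5-trimethoxyphenyl stays in place elsewhere on the molecule. The other comparison, 3,4,5-trimethoxyphenyl in place of 4-methoxyphenyl on an aromatic carbon with the carbonyl side held the same, gives a 2.1-fold higher number from compound 1 to compound 3 (0.32 log units; beyond the scatter), a modest step and the only one here beyond the scatter. Nothing available explains either result.

On these data alone, only phenyl and 3,4-dimethoxyphenyl appear on the carbonyl carbon, so it remains open how a carboxylic acid, an amine or a longer chain on that ring would read. A single modest step also cannot show whether the change on the aromatic carbon would act the same way with phenyl on the carbonyl carbon.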